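This account rests on a few compounds, and the source may have more. Where it says the series, first, only, none or still open, it means among the compounds named here.

Measured so far:
compound 1 `COc1cc(-c2cc(/C=C/C(=O)c3ccc(N)cc3)[nH]n2)cc(OC)c1OC` gives 92% in a functional assay on COLO 205 cells (Homo sapiens) for cytotoxicity, read by sulforhodamine B assay, with a stated time of 48 h, tested at 1 uM; a higher number here means a weaker effect of the compound at the concentration tested, a lower number a stronger effect
compound 2 `COc1ccc(C(=O)/C=C/c2cc(-c3cc(OC)c(OC)c(OC)c3)n[nH]2)cc1OC` gives 95% in this assay

Compound 2 stands alongside compound 1 on these numbers: the step of a number 3 percentage points higher from compound 1 to compound 2 (within the scatter) is within the scatter, so the two look alike. Compound 3 `COc1ccc(C(=O)/C=C/c2cc(-c3cc(OC)c(OC)c(OC)c3)n[nH]2)cc1` differs from compound 2 by hydrogen in place of methoxy on an aromatic carbon. For the measured compounds named here, no measured step removes a methoxy; the only measured step, a number 3 percentage points higher from compound 1 to compound 2 (within the scatter), exchanged the whole aryl group on the carbonyl carbon and changed little. Therefore the expected step is a number 2 percentage points lower from compound 2 to compound 3 (within the scatter). Compound 3 is estimated at 93%, between 80% and 102%.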

Compound 3, a percentage reported as activity, at one concentration (the size of the read-out at that concentration, not a potency): 94%
The estimate for compound 3 lay 1 percentage points below the measured number, and the stated range covers the measured number.
By their numbers in this assay, from the lowest: compounds 1, 3 and 2 (each within the scatter of the next).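

Going from 3,4-dimethoxyphenyl to 4-methoxyphenyl, with hydrogen in place of methoxy on the aromatic carbon, gives a number 1 percentage points lower from compound 2 to compound 3 (within the scatter) in this assay, so this methoxy makes no readable difference here. Methoxy in place of amino on an aromatic carbon gives a number 2 percentage points higher from compound 1 to compound 3 (within the scatter), so that exchange on the ring also leaves the read-out where it was. No supporting measurement bears on these results.

Still open, going by these compounds, is whether a carboxylic acid or a longer alkoxy chain on this ring would move the number beyond the scatter.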